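Adding One Fluorine to a Benzyl Group

This account rests on a few compounds, and the source may have more. Where it says the series, first, only, none or still open, it means among the compounds named here.

In a functional assay on KB cells (Homo sapiens) for antiproliferative activity, read by MTT assay, with a stated time of 48 h (on this read-out lower numbers stand for stronger inhibition and higher numbers for weaker inhibition), compound 1 (`Cc1c(Cc2ccccc2)c(=O)oc2cc(OCCOc3no[n+]([O-])c3S(=O)(=O)c3ccccc3)ccc12`) gives 4540 nM as its result. Among the measured compounds shown here, the only other measured compound, compound 2 (`COCCOc1no[n+]([O-])c1S(=O)(=O)c1ccccc1`), gives 3690 nM as its result. These two numbers lie within the usual scatter of each other, so neither can be ranked ahead. Compound 3 (`Cc1c(Cc2ccc(F)cc2)c(=O)oc2cc(OCCOc3no[n+]([O-])c3S(=O)(=O)c3ccccc3)ccc12`) has yet to be measured. It differs from compound 1 in one place (fluoro in place of hydrogen on an aromatic carbon): fluoro in place of hydrogen on an aromatic carbon, which turns benzyl into 4-fluorobenzyl. For the measured compounds named here, no measured pair shows what a single change does, so the forecast rests on little. The starting point is compound 1 at 4540 nM in this assay and no shift beyond the scatter is expected, in either direction. The estimated change (a 1.1-fold lower number from compound 1 to compound 3 (0.05 log units; within the scatter)) is correspondingly small. Compound 3 is expected to give about 4000 nM with a likely range from 1700 nM to 9500 nM once tested.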

Compound 3, half-maximal inhibitory concentration: 3230 nM
For compound 3 the middle estimate is 1.2-fold (0.09 log units) above the measured one; the range from low to high includes it.
By their numbers in this assay, from the lowest: compounds 3, 2 and 1 (each within the scatter of the next).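

Among the compounds shown here, this is the first step that changes only one place: turning benzyl into 4-fluorobenzyl gives a 1.4-fold lower number from compound 1 to compound 3 (0.15 log units; within the scatter) in this assay. A single fluoro can therefore stand in place of hydrogen on this aromatic carbon, para to a large group, without moving the number outside the normal scatter, so compound 1 and compound 3 cannot be ranked. Nothing available here speaks to why the number holds steady.

The compounds shown leave open whether a different group at this same carbon, such as chloro, methoxy, trifluoromethyl or an amine, would give a step beyond the scatter. They also leave open what fluoro would do on the other carbons of this ring.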